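This account rests on a few compounds, and the source may have more. Where it says the series, first, only, none or still open, it means among the compounds named here.

Measured so far:
compound 1 `O=S(=O)(Nc1ccc(-c2nc3ccccc3o2)cc1)c1ccc(F)c(C(F)(F)F)c1`: 28000 nM
compound 2 `Cc1ccccc1S(=O)(=O)Nc1ccc2oc(-c3ccccc3)nc2c1`: > 100000 nM

Notes. In an assay on cells for inhibition of HSP60/HSP10 (Homo sapiens), with a stated time of 60 min (a lower number here means a stronger inhibitor, a higher number a weaker inhibitor), compound 1 gives 28000 nM. Going by the values given here, for compound 2 the assay reports only a limit, > 100000 nM, so no number is known for it; this is the limit of > 100000 nM in this assay, at which 1 of the 2 values shown sits, and compound 2 therefore stands at the weak end of what the assay can report, with no measured step to any other compound.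

The next compound, compound 3 `O=S(=O)(Nc1ccc2oc(-c3ccccc3)nc2c1)c1ccc(Cl)cc1`, differs from compound 2 in one place: 4-chlorophenyl in place of 2-methylphenyl on a sulfonyl sulfur. Among the compounds with values here, no measured step between compounds exists, so the size of the change can only be expected. Compound 2 gives no number to build from, and compound 1 carries a different arrangement of the shared core.

From compound 2 to compound 3 the step is estimated at an at least 1.4-fold lower number from compound 2 to compound 3 (0.15 log units; that floor lies within the scatter), within the scatter or a modest gain. Compound 3 is expected at 70000 nM, with a range of 15000 nM to 250000 nM, and a fair chance that this assay again reports only a limit.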

Compound 3, half-maximal inhibitory concentration: > 100000 nM
Compound 3: a limit, no number; the forecaster's own chance of this, stated with the estimate: 50%; at least 1.4-fold (0.15 log units) between middle value and limit.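

Compound 2 and compound 3 each give only a limit in this assay, so no step between them can be read: the limit of > 100000 nM in this assay, at which 2 of the 3 values shown sit.

Still open, from the compounds shown here alone, is whether 4-chlorophenyl in place of 2-methylphenyl on a sulfonyl sulfur changes the number at all, since neither compound has a number.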